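Swapping a ring oxygen for a ring nitrogen

This account rests on a few compounds, and the source may have more. Where it says the series, first, only, none or still open, it means among the compounds named here.

Of the compounds shown here, three sharing one core have been measured in an ADME assay on Caco-2 cells (Homo sapiens) for permeability, read by LC-MS, in the apical to basolateral direction, with a stated time of 90 min; on this read-out lower numbers stand for lower permeability and higher numbers for higher permeability. Compound 1 `COc1ncc(-c2cc(OC3CCC3)c3ncnc(C)c3c2)cc1NS(=O)(=O)c1ccc(F)cc1F` gives 44 10^-6 cm/s. Compound 2 `COc1ncc(-c2cc(OC3CCCCC3)c3ncnc(C)c3c2)cc1NS(=O)(=O)c1ccc(F)cc1F` gives 16 10^-6 cm/s, and compound 3 `COc1ncc(-c2cc(OCC3CCOCC3)c3ncnc(C)c3c2)cc1NS(=O)(=O)c1ccc(F)cc1F` gives 31 10^-6 cm/s. Among these three numbers compound 3 stands second highest, with compound 1 nearest and compound 2 furthest away. The measured steps show a 2.8-fold lower number from compound 1 to compound 2 (0.44 log units; beyond the scatter), a 1.4-fold lower number from compound 1 to compound 3 (0.15 log units; within the scatter) and a 1.9-fold higher number from compound 2 to compound 3 (0.29 log units; within the scatter), so the spread across the whole set is small.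

Compound 4 `COc1ncc(-c2cc(OC3CCN(C)CC3)c3ncnc(C)c3c2)cc1NS(=O)(=O)c1ccc(F)cc1F` carries a different group at the same place: 1-methylpiperidin-4-yl in place of (oxan-4-yl)methyl on an oxygen on an aromatic ring. For the measured compounds named here, none of the three measured steps involves a nitrogen entering the ring, so no step bears directly on this change, and the expectation rests only on the narrow band the three compounds occupy. Within that band, the change from compound 1 to compound 2 and the change from compound 2 to compound 3 suggest that even a sizeable change of the group at this position moves the number only modestly. Going by the values given here, on that basis compound 4 is expected to land somewhat below compound 3, with a wide range because no comparable step has been measured: the estimated step is a 2.6-fold lower number from compound 3 to compound 4 (0.41 log units; beyond the scatter), giving an expected value of 12 10^-6 cm/s for compound 4, between 3 10^-6 cm/s and 35 10^-6 cm/s.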

Compound 4, apparent permeability: 4.5 10^-6 cm/s
Beside the measured number, compound 4's estimate is 2.7-fold (0.43 log units) above it, and the stated range covers the measured number.
By their numbers in this assay, from the lowest: compound 4; then compounds 2, 3 and 1 (each within the scatter of the next, the first and the last beyond it).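

Among the earlier compounds in this assay, changing the group on this oxygen moved the number only modestly, but 1-methylpiperidin-4-yl brings a larger drop, with a 6.9-fold lower number from compound 3 to compound 4 (0.84 log units; beyond the scatter) and a 9.8-fold lower number from compound 1 to compound 4 (0.99 log units; beyond the scatter) as the clearest measures of it. Even against compound 2, the earlier compound with the lowest number, there is a 3.6-fold lower number from compound 2 to compound 4 (0.55 log units; beyond the scatter) and so the new group stands apart from all three earlier ones. Since (oxan-4-yl)methyl and 1-methylpiperidin-4-yl have the same count of heavy atoms, the same count of hydrogen-bond acceptors and no net charge as computed, those counts do not track the number at this position, and the change itself is more than an exchange of ring atoms, as it also reads (oxan-4-yl)methoxy to (1-methylpiperidin-4-yl)oxy.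

Nothing given here accounts for the drop. The compounds shown also leave the ring nitrogen, its methyl group and the carbon link of the (oxan-4-yl)methyl group tangled together, and a comparison with oxan-4-yl directly on the oxygen, with (1-methylpiperidin-4-yl)methyl or with piperidin-4-yl would begin to pull them apart.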